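Hydroxy at the saturated ring carbon of compound 2

A few compounds are considered here, and "the series" means these few. Any claim that something is new, unique, unknown or untested is made for them only; others in the source may bear on it.

Compound 1 `CCS(=O)(=O)Nc1cc(C2CCCCC2)cc2c1CCCC2c1c[nH]cn1` gives 891 nM in an assay on isolated protein (Cricetulus griseus) for binding affinity to Alpha-1B adrenergic receptor (Mesocricetus auratus), read by radioligand binding (a lower number here means a stronger inhibitor, a higher number a weaker inhibitor), and compound 2 `CCS(=O)(=O)Nc1cccc2c1CCCC2c1c[nH]cn1` gives 1320 nM. For the measured compounds named here, the step of a 1.5-fold higher number from compound 1 to compound 2 (0.17 log units; within the scatter) leaves compound 2 within the scatter of compound 1, the only other number measured. Compound 3 `CCS(=O)(=O)Nc1cccc2c1CCCC2(O)c1c[nH]cn1` differs from compound 2 by hydroxy in place of hydrogen on a saturated ring carbon. Going by the values given here, no measured step concerns a saturated ring carbon; the one step known, a 1.5-fold higher number from compound 1 to compound 2 (0.17 log units; within the scatter), concerns an aromatic carbon and did not exceed the scatter, so nothing beyond the scatter is expected in either direction, though the uncertainty is wide. Compound 3 is expected to give 1300 nM, range 350 nM to 5000 nM. The step expected is a 1.0-fold lower number from compound 2 to compound 3 (0.01 log units; within the scatter).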

Compound 3, inhibition constant: < 10000 nM
Compound 3 gave a limit, no number; the forecaster's own chance of this, stated with the estimate: 10%; the middle value lies beyond the limit too.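

Compound 3 gives a limit and no number, so the step from compound 2 to compound 3 cannot be read: the limit of < 10000 nM in this assay, at which 1 of the 3 values shown sits.

The compounds shown leave open what hydroxy in place of hydrogen on a saturated ring carbon does in this assay.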